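A Nitro Group Added to a Well-Tolerated Compound

A few compounds are considered here, and "the series" means these few. Any claim that something is new, unique, unknown or untested is made for them only; others in the source may bear on it.

Compound 1 `Cn1c(-c2ccc([N+](=O)[O-])cc2)nc2cc(C(F)(F)F)ccc21`: > 100000 nM, a limit
Compound 2 `CC(=O)Nc1ccc(-c2nc3ccccc3[nH]2)cc1`: > 100000 nM, a limit

Both compounds were tested in an ADME assay on Vero cells (Chlorocebus sabaeus) for cytotoxicity; a higher number here means that more compound is tolerated, a lower number that less compound is tolerated. Compound 2 gives > 100000 nM, which is a limit of the assay and not a number. Neither measured compound has yet given a number: the limit of > 100000 nM in this assay, at which 2 of the 2 values shown sit.

Compound 3 `CC(=O)Nc1ccc(-c2nc3cc([N+](=O)[O-])ccc3[nH]2)cc1` differs from compound 2 in one place: nitro in place of hydrogen on an aromatic carbon. It has nitro in place of hydrogen on an aromatic carbon. For the measured compounds named here, no pair of measured compounds differs in one place, so no measured step indicates the size of this change. Compound 1 already carries a nitro group, and compound 1 gives > 100000 nM, again a limit. On that single case, only a small step or none beyond the scatter is expected in this assay, and any step that appears is expected to point towards less compound being tolerated. The expected change is an at least 1.2-fold lower number from compound 2 to compound 3 (0.09 log units; that floor lies within the scatter). For compound 3 the estimate is 80000 nM, with an expected range of 25000 nM to 100000 nM.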

Compound 3, half-maximal cytotoxic concentration: > 100000 nM
Compound 3: no number, only a limit; the forecaster's own chance of this, stated with the estimate: 60%; at least 1.2-fold (0.09 log units) between middle value and limit.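

In this assay compound 3 gives > 100000 nM, a limit and not a number. Compound 2 also sits at a limit, so no step can be read from compound 2 to compound 3. The compounds shown leave open how much of each is tolerated, and whether nitro in place of hydrogen on an aromatic carbon changes that at all: the limit of > 100000 nM in this assay, at which 3 of the 3 values shown sit.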